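The source may report more compounds than this note shows. Statements on the series, on what has been measured and on what is new or still open speak of the compounds shown alone.

Measured compounds:
compound 1 `O=S(=O)(NCCCNCc1ccccc1Cl)c1cc(C(F)(F)F)cc(C(F)(F)F)c1`
compound 2 `O=S(=O)(NCCCCNCc1ccc(Br)cc1)c1cc(C(F)(F)F)cc(C(F)(F)F)c1`
compound 3 `CCCCc1ccc(S(=O)(=O)NCCCCCCNCc2ccc(Br)cc2)cc1`

In a functional assay on MIA PaCa-2 cells (Homo sapiens) for inhibition, read by MTT assay, with a stated time of 72 h (a lower number here means a stronger inhibitor of growth, a higher number a weaker inhibitor of growth), compound 1 gives 11000 nM. In this assay compound 2 gives 2100 nM. In this assay compound 3 gives 5700 nM. Compound 1 therefore has the highest number of the three; its gap to compound 3 lies within the scatter, while the step of a 5.2-fold lower number from compound 1 to compound 2 (0.72 log units; beyond the scatter) is a modest one that goes beyond the scatter.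

Compound 4 `O=S(=O)(NCCCNCc1cccc2ccccc12)c1cc(C(F)(F)F)cc(C(F)(F)F)c1` is not yet measured. It differs from compound 1 in one place: naphthalen-1-yl in place of 2-chlorophenyl on a saturated chain carbon bound to an amine nitrogen. Going by the values given here, no measured step concerns this kind of change. Among the compounds with values here, the only single-point step available, from compound 1 to compound 2, alters both the halogen-bearing benzyl group and the chain length at the same time, so it speaks only loosely to what an exchange of aromatic ring at the benzylic carbon might do. Compound 2 and compound 3 share the same benzyl group and their values lie within the scatter of each other, which gives no further guidance. Compound 4 is therefore expected to give a number in this assay close to that of compound 1, with the estimated step of a 1.7-fold lower number from compound 1 to compound 4 (0.23 log units; within the scatter) lying within the scatter, perhaps tending lower. The estimate for compound 4 is 6500 nM, with a range from 2500 nM to 16000 nM.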

Compound 4, concentration for 50% growth inhibition: 2800 nM
Estimate against measurement, compound 4: 2.3-fold (0.37 log units) above; the measured number falls inside the stated range.
By their numbers in this assay, from the lowest: compounds 2 and 4 (each within the scatter of the next); then compounds 3 and 1 (each within the scatter of the next).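

In this assay, putting naphthalen-1-yl in place of 2-chlorophenyl on a saturated chain carbon bound to an amine nitrogen gives a 3.9-fold lower number from compound 1 to compound 4 (0.59 log units; beyond the scatter), a modest change that goes beyond the scatter. The earlier step, a 5.2-fold lower number from compound 1 to compound 2 (0.72 log units; beyond the scatter), altered the chain length together with the benzyl group, whereas this one leaves the chain and the sulfonamide part untouched and shows that the number responds to the aromatic group at this carbon alone. Nothing among the available data explains why the exchange of the chlorine-bearing ring for the two-ring group lowers the number.

The exchange removes the chlorine and adds a second six-membered aromatic ring at once, and the compounds shown do not separate these two changes, which leaves open what an unsubstituted phenyl or a naphthalen-2-yl group would give at this carbon. Going by these compounds alone, also open is whether naphthalen-1-yl would lower the number in the same way on a longer chain, such as the one in compound 2, or alongside the butyl-bearing sulfonamide part of compound 3.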